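The compounds below may be only part of what the source reports. "The series", "measured", "known", "first", "only" and "open" are said of these compounds alone.

In a functional assay on A549 cells (Homo sapiens) for cytotoxicity, read by WST assay, with a stated time of 24 h (on this read-out lower numbers stand for stronger inhibition and higher numbers for weaker inhibition), compound 1 `N#C/C(=C\c1cn(Cc2ccc(Cl)cc2)c2ccccc12)C(=O)c1c[nH]c2cc(F)ccc12` gives > 50000 nM, which is a limit of the assay and not a number. Going by the values given here, compound 2 `COc1ccc(Cn2cc(/C=C(\C#N)C(=O)c3c[nH]c4cc(OC)ccc34)c3ccccc32)cc1` gives 37400 nM, the only true number available, so it has no measured neighbour to be ranked against. Compound 3 `COc1ccc(Cn2cc(/C=C(\C#N)C(=O)c3c[nH]c4cc(F)ccc34)c3ccccc32)cc1` differs from compound 2 in one place: fluoro in place of methoxy on an aromatic carbon. This is fluoro in place of methoxy on an aromatic carbon, turning 6-methoxy-1H-indol-3-yl into 6-fluoro-1H-indol-3-yl. Among the compounds with values here, no measured pair isolates this change. Compound 1 carries the same fluoro group but also differs elsewhere, so it offers only a loose guide. The expected step of a 1.2-fold higher number from compound 2 to compound 3 (0.08 log units; within the scatter) is small, towards weaker inhibition, and probably not beyond the usual scatter. For compound 3 the estimated value is 45000 nM, with an expected range of 20000 nM to 90000 nM.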

Compound 3, half-maximal inhibitory concentration: > 50000 nM
Compound 3 was reported as a limit; the forecaster's own chance of this, stated with the estimate: 45%; at least 1.1-fold (0.04 log units) between middle value and limit.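

In this assay, the change from 6-methoxy-1H-indol-3-yl to 6-fluoro-1H-indol-3-yl now has a directly measured pair, which gives an at least 1.3-fold higher number from compound 2 to compound 3 (0.12 log units; that floor lies within the scatter). The value of compound 3 is a limit of the assay and not a number, so the pair gives no sign that fluoro at this position brings stronger inhibition than methoxy. The step from compound 1 to compound 3 cannot be read, and the true size of the fluoro step stays hidden, since the values of both compounds are limits: the limit of > 50000 nM in this assay, at which 2 of the 3 values shown sit.

The compounds shown carry only methoxy and fluoro at this position, so how an amine, a hydroxyl or a carboxylic acid on the same carbon would read remains open. Also open, on these data alone, is whether methoxy in place of chloro on the other aromatic carbon matters at all.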